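The source may report more compounds than this note shows. Statements on the series, on what has been measured and on what is new or still open speak of the compounds shown alone.

In a functional assay on K562 cells (Homo sapiens) for antiproliferative activity, read by MTT assay, with a stated time of 72 h (a higher number here means a weaker inhibitor, a lower number a stronger inhibitor), compound 1 `COc1cc(-c2ncnn2-c2cccc(F)c2)cc(OC)c1OC` gives > 10000 nM, which is a limit and not a number. Compound 2 `COc1cc(-n2ncnc2-c2ccc(C)cc2)cc(OC)c1OC` gives > 10000 nM, also a limit. Compound 3 `CCOc1cccc(-c2ncnn2-c2cc(OC)c(OC)c(OC)c2)c1` gives > 10000 nM, again a limit. Compound 1 therefore stands with the other two at the limit of > 10000 nM in this assay, at which 3 of the 3 values shown sit, and no exact potency is known for any of them. Compound 4 `COc1ccc(-n2ncnc2-c2cc(OC)c(OC)c(OC)c2)cc1` carries 4-methoxyphenyl in place of 3-fluorophenyl on an aromatic nitrogen. Among the measured compounds shown here, no measured step gives a size for this change, so the expectation is loose: a gain in potency of uncertain size, with a real chance of remaining at the limit. The expected step is an at least 5.0-fold lower number from compound 1 to compound 4 (0.69 log units; beyond the scatter). For compound 4 the estimated value is 2000 nM, with an expected range from 50 nM to 10000 nM.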

Compound 4, half-maximal inhibitory concentration: 3600 nM
Estimate against measurement, compound 4: 1.8-fold (0.26 log units) below; the range from low to high includes it.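

Placing 4-methoxyphenyl in place of 3-fluorophenyl on an aromatic nitrogen gives an at least 2.7-fold lower number from compound 1 to compound 4 (0.44 log units; beyond the scatter) in this assay. This shows that the group at this position can move a compound off the limit, and compound 4 is the only one of the four shown with an exact value. The step is only a lower bound on the change, because compound 1 sits at a limit: the limit of > 10000 nM in this assay, at which 3 of the 4 values shown sit.

From the compounds shown here alone, how large the change really is stays open. It is also unclear whether an amino or hydroxyl group in place of the methoxy group would keep this activity.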